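Fluoro for Ethynyl Carried onto a Second Core

The source may hold more compounds than are shown below. What is called first, only, known or untested is meant among the compounds shown, and "the series" means these compounds.

Compound 1 `COc1ccccc1N1C(=O)CSC1c1cc(F)cc(C(=O)NCCCCc2ccccc2)c1`, compound 2 `C#Cc1cc(C(=O)NCCCCc2ccccc2)cc(C2SCC(=O)N2c2ccccc2OC)c1` and compound 3 `C#Cc1cccc(N2C(=O)CSC2c2cccc(C(=O)NCCCCc3ccccc3)c2)c1` are closely related, and all three have been measured. In a functional assay on HOS-TE85 cells (Homo sapiens) for inhibition, read by CCK-8 assay, with a stated time of 72 h (on this read-out higher numbers stand for weaker inhibition and lower numbers for stronger inhibition), compound 1 gives 40.9 nM. In this assay compound 2 gives 40.8 nM, and compound 3 gives 149 nM in this assay, the highest of the three numbers. Compound 1 differs from compound 2 by fluoro in place of ethynyl on an aromatic carbon, and this change made a 1.0-fold higher number from compound 2 to compound 1 (0.00 log units; within the scatter). The difference between the core of compound 2 and the core of compound 3 is not broken down here.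

Compound 4 `O=C(NCCCCc1ccccc1)c1cccc(C2SCC(=O)N2c2cccc(F)c2)c1` has not yet been measured; it differs from compound 3 by fluoro in place of ethynyl on an aromatic carbon. This is the same kind of change as that from compound 2 to compound 1, but not the same one: in compound 2 the group sits meta to two large groups, whereas in compound 3 it sits meta to a large group. Because a 1.0-fold higher number from compound 2 to compound 1 (0.00 log units; within the scatter) showed no movement, the step expected for compound 4 is a 1.0-fold lower number from compound 3 to compound 4 (0.01 log units; within the scatter). The expectation rests on a single earlier instance of the change, made on a different core, so it is held loosely and the range is kept wide. Compound 4 is estimated to give 145 nM in this assay, with the result expected to fall between 60 nM and 350 nM.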

Compound 4, half-maximal inhibitory concentration in the HOS-TE85 assay: 32.4 nM
Compound 4: middle estimate off by 4.5-fold (0.65 log units), on the high side; the measured number lies below the stated range.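

In the HOS-TE85 assay compound 3 gives 149 nM and compound 4 gives 32.4 nM. In the HOS-TE85 assay the change of ethynyl to fluoro gave a 4.6-fold lower number from compound 3 to compound 4 (0.66 log units; beyond the scatter), so on the core of compound 3 it moved the number, whereas on the core of compound 2 it gave a 1.0-fold higher number from compound 2 to compound 1 (0.00 log units; within the scatter). Set side by side, the two instances disagree, and the outcome of this change on one core did not carry over to the other in this assay: the same change on two cores in the HOS-TE85 assay, a 1.0-fold higher number (0.00 log units; within the scatter) from compound 2 to compound 1 and a 4.6-fold lower number (0.66 log units; beyond the scatter) from compound 3 to compound 4, 4.6-fold (0.66 log units) apart, beyond the scatter of two such steps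

Within the data shown here, this comparison rests on only two pairs, and those pairs differ from each other in more than one place, so it does not show which of those differences sets the size of the step or why the step occurs. In a physicochemical assay for solubility, read by turbidimetry, measured as kinetic solubility, at pH 6.8 (a higher number here means a more soluble compound, a lower number a less soluble compound), compound 3 gives 10000 nM and compound 4 gives 10000 nM. In the physicochemical assay the same change gave no change at the digits printed from compound 3 to compound 4 (within the scatter).

On these data alone, it remains open whether chloro, a nitrile or a methyl group in place of the ethynyl group on the core of compound 3 would follow fluoro in the HOS-TE85 assay. Also open, as far as these compounds go, is whether the size of the step would hold with a methoxy group added to the core of compound 3 alone, or with a shorter chain on the amide.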